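The source may report more compounds than this note shows. Statements on the series, on what has been measured and on what is new or still open speak of the compounds shown alone.

Working notes on the series in a functional assay on MCF7 cells (Homo sapiens) for inhibition, read by MTT assay, with a stated time of 72 h, tested at 50 uM; a lower number here means less inhibition of growth, a higher number more inhibition of growth at the concentration tested.

Three compounds have been run. Compound 1 `C=CCc1ccc(OCc2cn(-c3ccccc3CO)nn2)c(O)c1` gives 40.4%. Compound 2 `C=CCc1cc(O)c(O)c(CN2CCC(CO)CC2)c1` gives 32.3%. Compound 3 `C#CCOc1ccc(CC=C)cc1O` gives 15.8%. Among these three numbers compound 2 stands second highest: the gap to compound 1 lies within the usual scatter, so no order between the two can be read, while the gap to compound 3, whose number is lower, lies beyond the scatter.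

The next compound to be measured is compound 4 `C=CCc1cc(O)c(O)c(CN2CCC(Cc3ccccc3)CC2)c1`. It differs from compound 2 in one place: phenyl in place of hydroxy on a saturated chain carbon bound to a saturated ring carbon. Cut one bond further out, the same difference reads hydroxymethyl to benzyl, the hydroxy leaving with one oxygen, one hydrogen-bond donor and one hydrogen-bond acceptor, the phenyl entering with six carbons and no donors or acceptors.

Among the compounds with values here, no step between measured compounds covers this kind of change, so its size in this assay is unknown; the expectation is a small upward move, at most just beyond the scatter. For compound 4 the estimated value is 42%, with a range from 26% to 60%, which means an expected step of a number 9.7 percentage points higher from compound 2 to compound 4 (within the scatter).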

Compound 4, percent growth inhibition at one concentration: 86.3%
Compound 4: the middle estimate sits 44.3 percentage points below what was measured; the whole stated range lies below it.
By their numbers in this assay, from the lowest: compound 3; then compounds 2 and 1 (each within the scatter of the next); then compound 4.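

In this assay, within the data shown here, the saturated chain carbon bound to a saturated ring carbon proves to be a place where one change moves the number strongly: phenyl in place of hydroxy gives a number 54 percentage points higher from compound 2 to compound 4 (beyond the scatter) and is the first step that can be read at all. The change removes the hydroxy with its hydrogen-bond donor and acceptor and brings in an aromatic ring of carbon only, so this single pair ties the rise to the loss of the one and the arrival of the other without separating them. No evidence on hand bears on why the number rises so far.

The compounds shown leave open whether the aromatic ring itself is required, since a cyclohexyl or a plain butyl group at the same place would give a carbon-only group without it. They also leave open how the number responds to a fluoro or methoxy substituent on the phenyl, to a longer chain between the phenyl and the saturated ring, or to an amine or a carboxylic acid in place of the phenyl.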